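Fluoro to hydrogen on the benzyl group of compound 3

This account rests on a few compounds, and the source may have more. Where it says the series, first, only, none or still open, it means among the compounds named here.

Compound 1 `COc1cc(-c2nnc(SCc3ccccc3)n2/N=C/c2ccccc2)cc(OC)c1OC`: in a functional assay on HepG2 cells (Homo sapiens) for cytotoxicity, read by MTT assay, with a stated time of 48 h (on this read-out lower numbers stand for stronger inhibition and higher numbers for weaker inhibition), compound 1 gives > 200000 nM, which is a limit of the assay and not a number.
Compound 2 `COc1ccc(/C=N/n2c(SC)nnc2-c2cc(OC)c(OC)c(OC)c2)c(OC)c1`: in this assay compound 2 gives > 200000 nM, again a limit.
Compound 3 `COc1ccc(/C=N/n2c(SCc3ccc(F)cc3)nnc2-c2cc(OC)c(OC)c(OC)c2)c(OC)c1`: in this assay compound 3 gives > 200000 nM, also a limit.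

Compound 3 therefore stands only at a limit, and no number is known for it. For the measured compounds named here, the single step between measured compounds, a step that the two limits leave unreadable from compound 2 to compound 3, is left unreadable by the two limits, in line with the limit of > 200000 nM in this assay, at which 3 of the 3 values shown sit. Compound 4 `COc1ccc(/C=N/n2c(SCc3ccccc3)nnc2-c2cc(OC)c(OC)c(OC)c2)c(OC)c1` differs from compound 3 by hydrogen in place of fluoro on an aromatic carbon. Going by the values given here, no measured step bears on this change, and all values shown sit at the limit. The author expects the step that the limit leaves unreadable from compound 3 to compound 4, that is, no movement beyond the scatter. Compound 4 is estimated at 300000 nM, with a range from 100000 nM to 1000000 nM, most likely reported again only as a limit.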

Compound 4, half-maximal inhibitory concentration: 60900 nM
Compound 4: the middle estimate sits 4.9-fold (0.69 log units) above what was measured, and the stated range ends above it.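

In this assay, hydrogen in place of fluoro on the aromatic carbon gives an at least 3.2-fold lower number from compound 3 to compound 4 (0.51 log units; beyond the scatter), the first readable effect of a change at this position. Phenyl in place of hydrogen on the saturated chain carbon bound to sulfur gives an at least 3.2-fold lower number from compound 2 to compound 4 (0.51 log units; beyond the scatter), and 2,4-dimethoxyphenyl in place of phenyl on the carbon with a double bond to nitrogen gives an at least 3.2-fold lower number from compound 1 to compound 4 (0.51 log units; beyond the scatter). The step between the other two compounds cannot be read, and only compound 4 gives a number: the limit of > 200000 nM in this assay, at which 3 of the 4 values shown sit.

From the compounds shown here alone, how the true size of these steps compares remains open, since each is bounded on one side only. Also open, going by these compounds, is how a chlorine, a methoxy group or an amine would read in place of the hydrogen on the benzyl ring.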